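A few compounds are considered here, and "the series" means these few. Any claim that something is new, unique, unknown or untested is made for them only; others in the source may bear on it.

Of the compounds shown here, three sharing one core have been measured in a functional assay on NCI-H1975 cells (Homo sapiens) for antiproliferative activity, read by MTT assay, with a stated time of 72 h; on this read-out higher numbers stand for weaker inhibition and lower numbers for stronger inhibition. Compound 1 `COc1cc(F)c(NC(=O)c2ccnc(Cl)c2)cc1Nc1nccc(-c2cn(C)c3ccccc23)n1` gives 4330 nM, compound 2 `COc1cc(N(C)CCN(C)C)c(NC(=O)c2ccnc(Cl)c2)cc1Nc1nccc(-c2cn(C)c3ccccc23)n1` gives 2050 nM, and compound 3 `COc1cc(N(C)C)c(NC(=O)c2ccnc(Cl)c2)cc1Nc1nccc(-c2cn(C)c3ccccc23)n1` gives 9200 nM, the highest number of the three. The steps of a 2.1-fold lower number from compound 1 to compound 2 (0.32 log units; beyond the scatter), a 2.1-fold higher number from compound 1 to compound 3 (0.33 log units; beyond the scatter) and a 4.5-fold higher number from compound 2 to compound 3 (0.65 log units; beyond the scatter) all alter the group standing on the aromatic carbon that carries fluoro in compound 1. Compound 4 `COc1cc(N(C)C)c(NC(=O)c2ccncn2)cc1Nc1nccc(-c2cn(C)c3ccccc23)n1` differs from compound 3 by pyrimidin-4-yl in place of 2-chloropyridin-4-yl on a carbonyl carbon. Among the measured compounds shown here, none of the measured steps touches this part of the molecule, so no step bears on the change and the data point in neither direction. Compound 4 is therefore expected to lie close to compound 3 in this assay, with a 1.0-fold lower number from compound 3 to compound 4 (0.01 log units; within the scatter) expected to be at most modest. The estimate for compound 4 is 9000 nM, with a range from 3000 nM to 27000 nM.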

Compound 4, half-maximal inhibitory concentration: 1250 nM
Compound 4: middle estimate off by 7.2-fold (0.86 log units), on the high side; measured number outside the range, below it.
By their numbers in this assay, from the lowest: compounds 4 and 2 (each within the scatter of the next); then compound 1; then compound 3.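

In this assay, pyrimidin-4-yl in place of 2-chloropyridin-4-yl on a carbonyl carbon gives a 7.4-fold lower number from compound 3 to compound 4 (0.87 log units; beyond the scatter) in a single step. Among the compounds shown here, the earlier compounds changed only the group on the aromatic carbon that carries fluoro in compound 1, so this is the first sign that the group on the carbonyl also moves the number. Nothing given here explains this step.

The loss of chlorine and the added ring nitrogen arrive together, and an unsubstituted pyridin-4-yl group would separate them. On these data alone, whether pyrimidin-4-yl gives a similar step alongside the (2-(dimethylamino)ethyl)(methyl)amino group of compound 2 also stays open.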